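Swapping the Phenyl Substituent on the Triazole Nitrogen

This account rests on a few compounds, and the source may have more. Where it says the series, first, only, none or still open, it means among the compounds named here.

Compound 3 `N#CC1=C(N)Oc2c(c3nc4ccccc4nc3c3ccccc23)C12C(=O)N(Cc1cnnn1-c1cccc(Cl)c1)c1ccccc12` is the only one of the three measured compounds to give a number in an ADME assay on L02 cells (Homo sapiens) for antiproliferative activity, read by MTT assay, with a stated time of 48 h (on this read-out higher numbers stand for weaker inhibition and lower numbers for stronger inhibition), where compound 3 reaches 35200 nM. Compound 1 `Cc1ccccc1-n1nncc1CN1C(=O)C2(C(C#N)=C(N)Oc3c2c2nc4ccccc4nc2c2ccccc32)c2ccccc21` gives only a limit of the assay in this assay, > 50000 nM. Compound 2 `Cc1cccc(-n2nncc2CN2C(=O)C3(C(C#N)=C(N)Oc4c3c3nc5ccccc5nc3c3ccccc43)c3ccccc32)c1` likewise gives only a limit, > 50000 nM. The step of an at least 1.4-fold lower number from compound 1 to compound 3 (0.15 log units; that floor lies within the scatter) and the step of an at least 1.4-fold lower number from compound 2 to compound 3 (0.15 log units; that floor lies within the scatter) are therefore read against that limit (the limit of > 50000 nM in this assay, at which 2 of the 3 values shown sit), and the step that the two limits leave unreadable from compound 1 to compound 2 cannot be read at all.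

Compound 4 `COc1ccccc1-n1nncc1CN1C(=O)C2(C(C#N)=C(N)Oc3c2c2nc4ccccc4nc2c2ccccc32)c2ccccc21` is not yet measured. It differs from compound 3 in one place: 2-methoxyphenyl in place of 3-chlorophenyl on an aromatic nitrogen. Within the data shown here, the only measured steps that touch this position are the two just named, both of which start from a limit and end at a number whose distance from that limit lies within the scatter. Among the measured compounds shown here, with no measured step large enough to read, no change beyond the scatter is expected for compound 4, and a return to the limit is the more likely outcome, since two of three measured compounds sit there. The step of a 1.4-fold higher number from compound 3 to compound 4 (0.15 log units; within the scatter) is therefore expected to be small. Compound 4 is estimated at 50000 nM in this assay, within 20000 nM to 120000 nM.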

Compound 4, half-maximal inhibitory concentration: > 50000 nM
Compound 4 was reported as a limit; the forecaster's own chance of this, stated with the estimate: 60%; the middle value sits exactly at the limit.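

The change to 2-methoxyphenyl on the triazole nitrogen gives an at least 1.4-fold higher number from compound 3 to compound 4 (0.15 log units; that floor lies within the scatter) in this assay, and the value for compound 4 is a limit of the assay, not a number. What is new here is the kind of group: 2-methoxyphenyl brings an oxygen and one hydrogen-bond acceptor, where 3-chlorophenyl has none, and even so compound 4 gives no number that could be compared with that of compound 3. The steps among compounds 1, 2 and 4 run from limit to limit and cannot be read, so compound 3 remains the one compound that goes against the pattern at this position: the limit of > 50000 nM in this assay, at which 3 of the 4 values shown sit.

The compounds shown leave open how this assay would read a phenyl ring carrying an amine or a carboxylic acid, or a longer alkyl chain on this nitrogen in place of the phenyl ring. They also leave open whether the outcome depends on the group itself or on where it sits on the phenyl ring, as methoxy and chloro each appear in only one place.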